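This account rests on a few compounds, and the source may have more. Where it says the series, first, only, none or still open, it means among the compounds named here.

In a functional assay on LNCaP cells (Homo sapiens) for cytotoxicity, read by MTT assay, with a stated time of 72 h (on this read-out higher numbers stand for weaker inhibition and lower numbers for stronger inhibition), compound 2 `COc1cc(/C=C/C(O)=C/C(=O)/C=C/C2=C(C)CCCC2(C)C)ccc1O` gives 20600 nM. Compound 1 `CCOc1ccc(/C=C(\C(=O)/C=C/C2=C(C)CCCC2(C)C)C(=O)/C=C/c2ccc(OCC)c(OCC)c2)cc1OCC` gives 14900 nM, within the scatter of the value for compound 2. Compound 3 `COc1cc(/C=C/C(O)=C/C(=O)/C=C/C2=C(C)CCCC2(C)C)cc(OC)c1O` gives 6200 nM, so it is the only one of the three that stands clearly apart from compound 2.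

Compound 4 `COc1ccc(/C=C/C(O)=C/C(=O)/C=C/C2=C(C)CCCC2(C)C)cn1` has not yet been measured. Its change from compound 2 is 6-methoxypyridin-3-yl in place of 4-hydroxy-3-methoxyphenyl on a double-bonded chain carbon bound to a double-bonded chain carbon.

Among the measured compounds shown here, only one measured step bears on this group: a 3.3-fold lower number from compound 2 to compound 3 (0.52 log units; beyond the scatter), with methoxy in place of hydrogen on an aromatic carbon. That step is modest and leaves the hydroxy group in place, so it is only a loose guide. For the measured compounds named here, no measured compound carries an aromatic ring with a hetero atom. A small shift towards a lower number is therefore expected, and nothing beyond the scatter. The expected step is a 1.5-fold lower number from compound 2 to compound 4 (0.17 log units; within the scatter). For compound 4 the estimated value is 14000 nM, with an expected range from 5500 nM to 35000 nM.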

Compound 4, half-maximal inhibitory concentration: 25100 nM
The estimate for compound 4 lay 1.8-fold (0.25 log units) below the measured number; the range from low to high includes it.
By their numbers in this assay, from the lowest: compound 3; then compounds 1, 2 and 4 (each within the scatter of the next).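

In this assay the exchange of 4-hydroxy-3-methoxyphenyl for 6-methoxypyridin-3-yl gives a 1.2-fold higher number from compound 2 to compound 4 (0.09 log units; within the scatter) and so shows that the number at this position stays within the scatter when the whole aromatic group is replaced, even though the hydrogen-bond donor is lost and the ring gains a hetero atom. The earlier step, a 3.3-fold lower number from compound 2 to compound 3 (0.52 log units; beyond the scatter), left the hydroxy group in place, so it could not show how the number responds once that group is gone. Nothing available here explains why the number holds.

Among the compounds shown here, the single exchange removes the hydroxy group and brings in the ring nitrogen together, so the share of each remains open. Also open, from the compounds shown here alone, is whether an amine or a carboxylic acid on the pyridine ring would move the number beyond the scatter, as the added methoxy of compound 3 did on the phenyl ring.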